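This account rests on a few compounds, and the source may have more. Where it says the series, first, only, none or still open, it means among the compounds named here.

Compound 2 `COc1cccc(-c2cnc(Nc3ccc4[nH]ncc4c3)o2)c1` was tested in an ADME assay on MT4 cells (Homo sapiens) for cytotoxicity, read by WST assay; a higher number here means that more compound is tolerated, a lower number that less compound is tolerated. Compound 2 gives > 90 uM, which is a limit of the assay rather than a measured number. Compound 1 `Clc1ccc(-c2cnc(Nc3ccc4[nH]ncc4c3)o2)cc1` likewise gives > 90 uM, again a limit. Both values sit at the limit of > 90 uM in this assay, at which 2 of the 2 values shown sit. Compound 3 `COc1cc(-c2cnc(Nc3ccc4[nH]ncc4c3)o2)ccc1Cl` differs from compound 2 by chloro in place of hydrogen on an aromatic carbon, a chloro in place of hydrogen on an aromatic carbon. Going by the values given here, no step between measured compounds is available for comparison, so in this assay the expected step is a number no higher from compound 2 to compound 3 (the limit leaves the size open), none beyond the usual scatter. Compound 3 is estimated at 90 uM, within a range from 40 uM to 150 uM, and is expected to be reported as a limit again.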

Compound 3, half-maximal toxic concentration: 80 uM
Compound 3: middle estimate off by 1.1-fold (0.05 log units), on the high side; the range from low to high includes it.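

In this assay compound 3 gives 80 uM, the only real number among these compounds. Chloro ortho to a methoxy group, and methoxy added beside the chloro of the other compound, give an at least 1.1-fold lower number from compound 2 to compound 3 (0.05 log units; that floor lies within the scatter) and an at least 1.1-fold lower number from compound 1 to compound 3 (0.05 log units; that floor lies within the scatter), so neither change can yet be told from scatter. Both steps are only floors, and their true size stays hidden: the limit of > 90 uM in this assay, at which 2 of the 3 values shown sit.

As far as these compounds go, how large either step really is remains open. So does whether an amine or a carboxylic acid in place of the chloro would give a number clearly lower.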